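Compound 2 to compound 3: one carbon ring exchanged

A few compounds are considered here, and "the series" means these few. Any claim that something is new, unique, unknown or untested is made for them only; others in the source may bear on it.

In an ADME assay on KB cells (Homo sapiens) for cytotoxicity, with a stated time of 48 h (on this read-out higher numbers stand for weaker inhibition and lower numbers for stronger inhibition), compound 1 `CC1=CCC[C@](C)(CC/C(C)=C/CC2=C(O)C(=O)C=C(N[C@H](C(=O)O)[C@@H](C)O)C2=O)[C@@H]1C` gives > 10 ug/mL, which is a limit. Compound 2 `C=C1[C@H](C)CCC[C@]1(C)CC/C(C)=C/CC1=C(O)C(=O)C=C(N[C@H](C(=O)O)[C@H](C)O)C1=O` gives > 10 ug/mL, also a limit and not a number. Within the data shown here, the series so far holds only (the limit of > 10 ug/mL in this assay, at which 2 of the 2 values shown sit). Compound 3 `CC1=CCC[C@](C)(CC/C(C)=C/CC2=C(O)C(=O)C=C(N[C@H](C(=O)O)[C@H](C)O)C2=O)[C@@H]1C` differs from compound 2 by a group of 9 heavy atoms (9 carbon; one six-membered non-aromatic ring of carbon only) in place of a group of 9 heavy atoms (9 carbon; one six-membered non-aromatic ring of carbon only), on a saturated chain carbon, two bonds along the chain from a double-bonded chain carbon, with 1,2,3-trimethylcyclohex-3-en-1-yl as the entering group. Among the measured compounds shown here, no measured step is available to size this change, so no shift beyond the scatter is expected in this assay. The estimated size is a step that the limit leaves unreadable from compound 2 to compound 3. Compound 3 is estimated at 15 ug/mL, with an expected range of 8 ug/mL to 30 ug/mL.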

Compound 3, half-maximal inhibitory concentration: > 10 ug/mL
Compound 3 gave a limit, no number (the forecaster's own chance of this, stated with the estimate: 85%); the middle value is on the limit's open side.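

No step can be read between compound 1, compound 2 and compound 3 in this assay, as all three values are limits: the limit of > 10 ug/mL in this assay, at which 3 of the 3 values shown sit.

The compounds shown leave open whether the ring exchange or the difference in drawn configuration affects cytotoxicity at all.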